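The compounds below may be only part of what the source reports. "The series", "measured", "known", "first", "only" and "open" are said of these compounds alone.

Measured so far:
- compound 1, `Cc1nc(NC(C)C)nc(N[C@@H]2C[C@H](CO)[C@@H](O)[C@H]2O)c1-c1nc2ccccc2s1`: 8420 ng.h/mL
- compound 2, `Cc1nc(NC(C)(C)C)nc(N[C@@H]2C[C@H](CO)[C@@H](O)[C@H]2O)c1-c1nc2ccccc2s1`: 2220 ng.h/mL
- compound 3, `CCOCCNc1nc(C)c(-c2nc3ccccc3s2)c(N[C@@H]2C[C@H](CO)[C@@H](O)[C@H]2O)n1`: 1100 ng.h/mL

In an ADME assay on the whole organism (plasma) for pharmacokinetics, with Rattus norvegicus as the target, with a stated time of 6 h, at a dose of 10 mg/kg by the oral route (on this read-out higher numbers stand for higher exposure at the dose given and lower numbers for lower exposure), compound 1 gives the highest of these three numbers. The change methyl in place of hydrogen on a saturated chain carbon bound to a nitrogen on an aromatic ring and two saturated chain carbons turns compound 1 into compound 2, and in this assay it brought a 3.8-fold lower number from compound 1 to compound 2 (0.58 log units; beyond the scatter). The difference between the core of compound 1 and that of compound 3 is 2-ethoxyethyl in place of isopropyl on a nitrogen on an aromatic ring, and across it the number moved by a 7.7-fold lower number from compound 1 to compound 3 (0.88 log units; beyond the scatter). Compound 2 and compound 3 differ by a 2.0-fold lower number from compound 2 to compound 3 (0.30 log units; within the scatter).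

Compound 4, `Cc1nc(NCCOC(C)C)nc(N[C@@H]2C[C@H](CO)[C@@H](O)[C@H]2O)c1-c1nc2ccccc2s1`, has not yet been measured in this assay. It arises from compound 3 by methyl in place of hydrogen on a saturated chain carbon bound to an oxygen on a saturated carbon and a saturated chain carbon. For the measured compounds named here, this is the same kind of change as the one from compound 1 to compound 2, a methyl entering for a hydrogen, but the place is not the same: there the carbon was bound to a nitrogen on an aromatic ring and two saturated chain carbons, here it is bound to an oxygen on a saturated carbon and a saturated chain carbon. Resting on the step from compound 1 to compound 2, a 3.8-fold lower number from compound 1 to compound 2 (0.58 log units; beyond the scatter), a step of about a 2.8-fold lower number from compound 3 to compound 4 (0.44 log units; beyond the scatter) is expected from compound 3 to compound 4, with less certainty given the different place. Compound 4 is therefore estimated at 400 ng.h/mL, between 130 ng.h/mL and 1200 ng.h/mL.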

Compound 4, area under the concentration-time curve: 426 ng.h/mL
Estimate against measurement, compound 4: 1.1-fold (0.03 log units) below, and the stated range covers the measured number.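

Methyl in place of hydrogen brought a 2.6-fold lower number from compound 3 to compound 4 (0.41 log units; beyond the scatter) in this assay, while 2-isopropoxyethyl on a nitrogen on an aromatic ring brought a 5.2-fold lower number from compound 2 to compound 4 (0.72 log units; beyond the scatter) in place of tert-butyl and a 20-fold lower number from compound 1 to compound 4 (1.30 log units; beyond the scatter) in place of isopropyl. For the compounds shown here, both methyl steps go the same way, and their sizes cannot be told apart, so on these two cores the change carries over: the same change on two cores in this assay, a 3.8-fold lower number (0.58 log units; beyond the scatter) from compound 1 to compound 2 and a 2.6-fold lower number (0.41 log units; beyond the scatter) from compound 3 to compound 4, 1.5-fold (0.17 log units) apart, within the scatter of two such steps This rests on only two pairs, with the methyl entering at a different place in each, so it does not show that the change would behave alike on other cores or at other places, and it gives no cause for the lower numbers.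

On these data alone, it remains open how exposure would respond to a longer chain, an amine or a carboxylic acid in place of 2-isopropoxyethyl on that nitrogen. Also open, as far as these compounds go, is whether a methyl in place of hydrogen would lower the number when placed on such a group.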